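The source may report more compounds than this note shows. Statements on the series, on what has been measured and on what is new or still open speak of the compounds shown alone.

In an ADME assay on HEK293 cells (Homo sapiens) for cytotoxicity, read by resazurin assay, with a stated time of 48 h (a lower number here means that less compound is tolerated, a higher number that more compound is tolerated), compound 1 `O=S(=O)(Nc1ccc(-c2nc3ccccc3o2)cc1)c1cccc(F)c1` gives > 100000 nM, which is a limit of the assay. Compound 2 `O=S(=O)(Nc1ccc(-c2nc3ccccc3o2)cc1)c1cccs1` gives > 100000 nM, also a limit. Compound 3 `O=S(=O)(Nc1ccc(-c2nc3ccccc3o2)cc1)c1ccccc1O` gives > 100000 nM, again a limit and not a number. Going by the values given here, the series so far therefore reads as the limit of > 100000 nM in this assay, at which 3 of the 3 values shown sit.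

Compound 4 `CCc1ccc(S(=O)(=O)Nc2ccc(-c3nc4ccccc4o3)cc2)cc1` carries 4-ethylphenyl in place of 2-hydroxyphenyl on a sulfonyl sulfur.

Three measured steps change this same place: a step that the two limits leave unreadable from compound 1 to compound 2, a step that the two limits leave unreadable from compound 1 to compound 3 and a step that the two limits leave unreadable from compound 2 to compound 3. None has a readable size, and none gives a direction.

No step beyond the usual scatter is expected in this assay, and a further limit is the likeliest outcome for compound 4. This expectation rests on compound 3, whose reading of > 100000 nM is a limit, so a measurable value cannot be excluded.

The expected result is a number no higher from compound 3 to compound 4 (the limit leaves the size open). The estimated value for compound 4 is 100000 nM, with an expected range from 40000 nM to 200000 nM.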

Compound 4, half-maximal cytotoxic concentration: 82000 nM
For compound 4 the middle estimate is 1.2-fold (0.09 log units) above the measured one, and the stated range covers the measured number.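

In this assay, going by these compounds alone, compound 4 gives 82000 nM, the first reading at this sulfonyl position that is a number and not a limit. The steps are an at least 1.2-fold lower number from compound 3 to compound 4 (0.08 log units; that floor lies within the scatter), an at least 1.2-fold lower number from compound 2 to compound 4 (0.08 log units; that floor lies within the scatter) and an at least 1.2-fold lower number from compound 1 to compound 4 (0.08 log units; that floor lies within the scatter); each floor lies within the scatter, so 4-ethylphenyl is not shown to differ meaningfully from the other three groups, and the steps among those three cannot be read. The series remains mostly at its ceiling: the limit of > 100000 nM in this assay, at which 3 of the 4 values shown sit.

Left open is whether a longer chain in place of the ethyl, or an amine or a carboxylic acid on the phenyl ring, would give a number clearly lower than that of compound 4. Also open, from the compounds shown here alone, is how far the true values of compounds 1, 2 and 3 lie from that of compound 4, since each of those three readings is a limit.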